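Ketone in Place of Ester: Expectation for Compound 4

The compounds below may be only part of what the source reports. "The series", "measured", "known", "first", "only" and "open" are said of these compounds alone.

Of the compounds shown here, three have been measured in a functional assay on RAW264.7 cells (Mus musculus), read by fluorescence; on this read-out higher numbers stand for weaker inhibition and lower numbers for stronger inhibition. Compound 1 `CCOC(=O)C1=CCCCC1S(=O)(=O)Cc1ccccc1` gives 101 nM, compound 2 `CCOC(=O)C1=CCCCC1S(=O)(=O)Cc1cc2ccccc2s1` gives 101 nM, and compound 3 `CCCCOC(=O)C1=CCCCC1S(=O)(=O)Cc1ccc(F)cc1Cl` gives 103 nM. Compound 3 holds the highest of the three numbers, yet its value lies within the scatter of both compound 1 and compound 2, so nothing separates the three. Compound 4 `CCC(=O)C1=CCCCC1S(=O)(=O)Cc1ccc(F)cc1Cl` has not been measured; it differs from compound 3 by ethyl in place of butoxy on a carbonyl carbon, a change that, taken one bond further out, reads butoxycarbonyl to propanoyl. Within the data shown here, no measured pair shows this change, so its size is unknown. The step of a 1.5-fold higher number from compound 3 to compound 4 (0.16 log units; within the scatter) in this assay is expected to be small, with no set direction. Compound 4 is therefore estimated at 150 nM, within a range from 50 nM to 500 nM.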

Compound 4, half-maximal inhibitory concentration: 64 nM
Estimate against measurement, compound 4: 2.3-fold (0.37 log units) above, within the range that was stated.
By their numbers in this assay, from the lowest: compounds 4, 1, 2 and 3 (each within the scatter of the next).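

In this assay, among these compounds, the one pair differing in a single place gives a 1.6-fold lower number from compound 3 to compound 4 (0.21 log units; within the scatter) with ethyl in place of butoxy on a carbonyl carbon. This position therefore keeps a number of the same order when the ester becomes a ketone, so the butoxy group is not required here. Nothing shown gives a reason for this outcome. The compounds shown leave open whether a longer chain, an amine or a carboxylic acid in place of ethyl would hold the number in this range.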